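Cyclopentyl on the sulfonyl sulfur at the clearance limit

The compounds below may be only part of what the source reports. "The series", "measured", "known", "first", "only" and "open" are said of these compounds alone.

Compound 1 (`CC(C)(CO)S(=O)(=O)c1cccc(NC(=O)c2cccnc2N2CCC3(CC2)CC3)c1`) and compound 2 (`CC(C)(C)NS(=O)(=O)c1cccc(NC(=O)c2cccnc2N2CCC3(CC2)CC3)c1`) differ in one place, on a sulfonyl sulfur. In an ADME assay on microsomes from liver (Mus musculus) for metabolic stability, read by LC-MS, with a stated time of 40 min, tested at 0.5 uM (on this read-out lower numbers stand for slow clearance and higher numbers for fast clearance), compound 1 gives > 399 mL.min-1.g-1 as a limit of the assay and not a number. Compound 2 gives > 399 mL.min-1.g-1 as a limit as well, so it stands without a readable number. Among the compounds with values here, the series so far offers the limit of > 399 mL.min-1.g-1 in this assay, at which 2 of the 2 values shown sit, and nothing else in this read-out.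

Compound 3 (`O=C(Nc1cccc(S(=O)(=O)C2CCCC2)c1)c1cccnc1N1CCC2(CC1)CC2`) carries cyclopentyl in place of (tert-butyl)amino on a sulfonyl sulfur, counted as cyclopentyl in place of (tert-butyl)amino on a sulfonyl sulfur and read one bond further out as (tert-butyl)sulfamoyl to cyclopentylsulfonyl. Within the data shown here, the one measured step at this place is a step that the two limits leave unreadable from compound 1 to compound 2 and it gives no size to carry over. The expectation therefore rests on compound 2 at > 399 mL.min-1.g-1 and points to fast clearance again. In this assay the expected step is a step that the limit leaves unreadable from compound 2 to compound 3 and it is taken as nothing beyond the scatter, with no direction claimed. Compound 3 is estimated at 450 mL.min-1.g-1 with an expected range of 220 mL.min-1.g-1 to 900 mL.min-1.g-1 and may well return a limit again.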

Compound 3, intrinsic clearance in microsomes: > 399 mL.min-1.g-1
Compound 3 was reported as a limit; the forecaster's own chance of this, stated with the estimate: 70%; the middle value does not contradict the limit.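

In this assay compound 3 gives > 399 mL.min-1.g-1, a limit of the assay and not a number. Within the data shown here, no step among compound 1, compound 2 and compound 3 can be read. The compounds shown leave open how the three groups on the sulfonyl sulfur compare in clearance: the limit of > 399 mL.min-1.g-1 in this assay, at which 3 of the 3 values shown sit.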